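Methylsulfanyl for chloro on a fused core: compound 4

A few compounds are considered here, and "the series" means these few. Any claim that something is new, unique, unknown or untested is made for them only; others in the source may bear on it.

Measured so far:
- compound 1, `CSc1cc(C)nc(NC(=S)NC(=O)c2c(-c3ccc(Cl)cc3Cl)noc2C)n1`: 32.8%
- compound 2, `Cc1cc(Cl)nc(NC(=S)NC(=O)c2c(-c3ccc(Cl)cc3Cl)noc2C)n1`: 28.9%
- compound 3, `COc1cc(Cl)nc2n/c(=N/C(=O)c3c(-c4ccc(Cl)cc4Cl)noc3C)sn12`: 19.3%

Of the compounds shown here, three have been tested in a functional assay on the whole organism for inhibition, with Chenopodium ficifolium as the target, with a stated time of 72 h, tested at 10 mg/L; on this read-out higher numbers stand for more inhibition of growth at the one concentration tested and lower numbers for less inhibition of growth. Compound 1 gives 32.8%, compound 2 gives 28.9%, and compound 3 gives 19.3%. Compound 3 has the lowest of the three numbers; its gap to compound 2 lies within the scatter, while its gap to compound 1 lies beyond it.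

Compound 1 and compound 2 share a core and differ in one place: methylsulfanyl in place of chloro on an aromatic carbon. That change made a step of a number 3.9 percentage points higher from compound 2 to compound 1 (within the scatter).

Compound 4, `COc1cc(SC)nc2n/c(=N/C(=O)c3c(-c4ccc(Cl)cc4Cl)noc3C)sn12`, is not yet measured. It stands to compound 3 as compound 1 stands to compound 2: methylsulfanyl in place of chloro on an aromatic carbon. The difference between the core of compound 3 and that of compound 2 is not broken down here. The surroundings of the place are not the same: in compound 3 the ring is part of a fused or bridged system of two rings, the carbon is meta to a fused ring, meta to a methoxy group and para to a fused ring, whereas in compound 2 it is meta to a large group and meta to a methyl group. It is therefore the same kind of change, not the same change.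

Because the step of a number 3.9 percentage points higher from compound 2 to compound 1 (within the scatter) lay within the scatter, a step of about a number 3.7 percentage points higher from compound 3 to compound 4 (within the scatter) is expected from this change on the fused core as well. Compound 4 is therefore estimated at 23%, roughly between 10% and 37%.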

Compound 4, percent growth inhibition at one concentration: 23.8%
Beside the measured number, compound 4's estimate is 0.8 percentage points below it; the range from low to high includes it.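

In this assay, methylsulfanyl in place of chloro on an aromatic carbon gave a number 4.5 percentage points higher from compound 3 to compound 4 (within the scatter) on the core of compound 3, and the two steps of this change agree across the two cores: the same change on two cores in this assay, a number 3.9 percentage points higher (within the scatter) from compound 2 to compound 1 and a number 4.5 percentage points higher (within the scatter) from compound 3 to compound 4, 0.6 percentage points apart, within the scatter of two such steps.

The change therefore carried from one core to the other without any measurable difference in its size, even though its surroundings on the two cores are not the same. This does not show that the change improves growth inhibition on either core, since both steps lie within the scatter, and two cores tested at one concentration give no rule for any further core.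

The compounds shown leave open whether a different group on that aromatic carbon, such as an amine or a longer chain like butylsulfanyl, would give a step beyond the scatter. They also leave open how this change would read at other concentrations of the test.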